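The source may hold more compounds than are shown below. What is called first, only, known or untested is meant among the compounds shown, and "the series" means these compounds.

Among the two compounds measured in an assay on isolated protein for inhibition of Bile acid receptor (Homo sapiens), read by TR-FRET and LanthaScreen (a lower number here means a stronger inhibitor, a higher number a weaker inhibitor), compound 2 `Cn1c([C@@H](N2C(=O)CN(c3ccc(Oc4ccccc4)cc3)C2=O)C(C)(C)C)nc2ccc(C(=O)O)cc21` gives 77100 nM, the highest of the two numbers; its nearest neighbour, compound 1 `Cn1c([C@H](CC2CCCCC2)N2C(=O)CN(c3ccc(Oc4ccccc4)cc3)C2=O)nc2ccc(C(=O)O)cc21`, gives 24400 nM. For the measured compounds named here, the one step among the measured pair, a 3.2-fold higher number from compound 1 to compound 2 (0.50 log units; beyond the scatter), put tert-butyl in place of cyclohexylmethyl on a saturated chain carbon bound to an amide-type nitrogen in a ring and an aromatic carbon. Compound 3 `CC(C)C[C@@H](c1nc2ccc(C(=O)O)cc2n1C)N1C(=O)CN(c2ccc(Oc3ccccc3)cc2)C1=O` carries isobutyl in place of tert-butyl on a saturated chain carbon bound to an amide-type nitrogen in a ring and an aromatic carbon; the two compounds have the same atoms, joined differently. Going by the values given here, only that single step bears on the change, and it points to the group at this position shifting the number by a modest amount. Compound 3 is therefore expected to move back toward the number of compound 1, and the step of a 1.9-fold lower number from compound 2 to compound 3 (0.28 log units; within the scatter) is estimated as a modest lowering. Compound 3 is expected to give 40000 nM, in a range from 15000 nM to 110000 nM.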

Compound 3, half-maximal inhibitory concentration: 43400 nM
Beside the measured number, compound 3's estimate is 1.1-fold (0.04 log units) below it; the range from low to high includes it.
By their numbers in this assay, from the lowest: compounds 1, 3 and 2 (each within the scatter of the next, the first and the last beyond it).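

In this assay, isobutyl in place of tert-butyl, two groups of the same atoms joined differently, gives (a 1.8-fold lower number from compound 2 to compound 3 (0.25 log units; within the scatter)), so at this position the rearrangement alone is not told apart from the scatter of repeated measurements. From the other side, isopropyl in place of cyclohexyl on a saturated chain carbon gives (a 1.8-fold higher number from compound 1 to compound 3 (0.25 log units; within the scatter)), so compound 3 cannot be separated from compound 1 or from compound 2, although those two remain apart from each other. No measurement here bears on why the numbers fall as they do.

On these data alone, whether a chain bearing an amine or a hydroxyl group, or a longer chain such as n-hexyl, would shift the number at this carbon stays open. The three compounds also leave open how far a change of this group alone can move the number.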